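From 4-Methylphenyl to 4-Chlorophenyl

A few compounds are considered here, and "the series" means these few. Any claim that something is new, unique, unknown or untested is made for them only; others in the source may bear on it.

For the measured compounds named here, in a functional assay on A549 cells (Homo sapiens) for cytotoxicity (a higher number here means a weaker inhibitor, a lower number a stronger inhibitor), compound 3 `Cc1ccc(S(=O)(=O)N2CC(c3ccccc3)NC2=O)cc1` gives 12500 nM, the lowest of the three numbers so far. Compound 4 `O=C1NC(c2ccccc2)CN1S(=O)(=O)c1ccc(Cl)cc1` differs from it in one place, chloro in place of methyl on an aromatic carbon. Going by the values given here, the only measured single-place step, a 1.0-fold lower number from compound 1 to compound 2 (0.01 log units; within the scatter), swapped bromo for methyl at another place and stayed within the scatter. Compound 1 `O=C1NC(c2ccc(Br)cc2)CN1S(=O)(=O)c1ccc(Cl)cc1` at 161000 nM and compound 2 `Cc1ccc(C2CN(S(=O)(=O)c3ccc(Cl)cc3)C(=O)N2)cc1` at 158000 nM already carry 4-chlorophenyl, but each also differs from compound 3 in a second place, so the data cannot separate the two changes. A moderate rise in this assay is therefore expected, an estimated 3.2-fold higher number from compound 3 to compound 4 (0.51 log units; beyond the scatter). The estimate for compound 4 is 40000 nM, with an expected range from 12000 nM to 150000 nM.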

Compound 4, half-maximal inhibitory concentration: 9470 nM
Compound 4: the middle estimate sits 4.2-fold (0.63 log units) above what was measured; the measured number lies below the stated range.
By their numbers in this assay, from the lowest: compounds 4 and 3 (each within the scatter of the next); then compounds 2 and 1 (each within the scatter of the next).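

Changing 4-methylphenyl to 4-chlorophenyl makes no real difference in this assay, with a 1.3-fold lower number from compound 3 to compound 4 (0.12 log units; within the scatter) at this place on the compound. With chloro held fixed, the large steps come from the other aromatic ring: a 17-fold lower number from compound 2 to compound 4 (1.22 log units; beyond the scatter) when hydrogen replaces methyl, and a 17-fold lower number from compound 1 to compound 4 (1.23 log units; beyond the scatter) when hydrogen replaces bromo, so that second place matters far more among these compounds. No evidence at hand explains these differences. Going by these compounds, whether an amine or a carboxylic acid at either place would shift the number remains open. Also open, on these data alone, is whether the large steps at the second place would hold with 4-methylphenyl in place of 4-chlorophenyl.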